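Removing a methyl group from compound 2

This account rests on a few compounds, and the source may have more. Where it says the series, first, only, none or still open, it means among the compounds named here.

- compound 1 `CC1=NN(c2ccccc2)C(=O)[C@]12C(=O)C=CC[C@H]2c1ccc(C)cc1` gives 5720 nM
- compound 2 `CC1=NN(c2ccccc2)C(=O)[C@]12C(=O)C=CC[C@H]2c1cccc(C)c1` gives 10300 nM

Both values come from a functional assay on MDA-MB-231 cells (Homo sapiens) for inhibition, read by MTT assay, with a stated time of 72 h (on this read-out lower numbers stand for stronger inhibition and higher numbers for weaker inhibition), and the two compounds share one core. Within the data shown here, compound 2 cannot be told apart from compound 1 on these numbers: the only measured step is a 1.8-fold higher number from compound 1 to compound 2 (0.26 log units; within the scatter) and it does not exceed the usual scatter of repeated measurements.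

Among the measured compounds shown here, the next compound, compound 3 `CC1=NN(c2ccccc2)C(=O)[C@]12C(=O)C=CC[C@H]2c1ccccc1`, has no measurement yet. Its difference from compound 2 is hydrogen in place of methyl on an aromatic carbon, in words hydrogen in place of methyl on an aromatic carbon, so 3-methylphenyl becomes phenyl. The measured step bears on this only indirectly, as it shifted the methyl group and did not remove it. For the measured compounds named here, no measured pair shows what losing the methyl does. Going by the values given here, with only that small step to go on, no step beyond the scatter is expected in this assay, and no direction can be favoured. The expected change is a 1.4-fold lower number from compound 2 to compound 3 (0.14 log units; within the scatter) and it remains an estimate. For compound 3 the estimate is 7500 nM, expected to lie between 3500 nM and 16000 nM in repeat measurements.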

Compound 3, half-maximal inhibitory concentration: 5800 nM
Compound 3: middle estimate off by 1.3-fold (0.11 log units), on the high side; the range from low to high includes it.
By their numbers in this assay, from the lowest: compounds 1, 3 and 2 (each within the scatter of the next).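

Compound 3 supplies the comparison that was missing. The methyl group is now removed from the ring rather than shifted around it. In this assay that removal can be read directly (a 1.8-fold lower number from compound 2 to compound 3 (0.25 log units; within the scatter)), and the same change can be read from the other methyl compound (a 1.0-fold higher number from compound 1 to compound 3 (0.01 log units; within the scatter)). Neither step lies beyond the scatter, so a methyl group at either of the two places shown cannot be told apart from plain hydrogen on this six-membered aromatic ring, and the three compounds form one group on these numbers, with no order among them. No measurement is available that would explain why these numbers lie so close together.

The compounds shown carry only hydrogen or methyl on this ring, so it remains open whether a different group, such as a methoxy group, a chlorine atom, an amine or a carboxylic acid, would give a step beyond the scatter. From the compounds shown here alone, it also remains open whether changes elsewhere on the shared core would move the number further than any change seen here.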